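This account rests on a few compounds, and the source may have more. Where it says the series, first, only, none or still open, it means among the compounds named here.

Results in a functional assay on HCT-116 cells (Homo sapiens) for antiproliferative activity, read by WST assay, with a stated time of 72 h (on this read-out higher numbers stand for weaker inhibition of growth and lower numbers for stronger inhibition of growth), so far:
- Compound 1 `O=C(NO)c1cnc(N2C[C@@H]3[C@H](C2)[C@H]3NS(=O)(=O)c2cccs2)nc1`: > 10000 nM (a limit of the assay, not a number)
- Compound 2 `O=C(NO)c1cnc(N2C[C@@H]3[C@H](C2)[C@H]3NCC2CCCCC2)nc1`: 160 nM

Among the compounds with values here, compound 2 holds the only true number in this assay. For compound 1 the result is only a limit, (the limit of > 10000 nM in this assay, at which 1 of the 2 values shown sits).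

Compound 3 `O=C(NO)c1cnc(N2C[C@@H]3[C@H](C2)[C@H]3NCc2ccc(F)cc2)nc1` differs from compound 2 by 4-fluorophenyl in place of cyclohexyl on a saturated chain carbon bound to an amine nitrogen. Within the data shown here, the single measured step, an at least 62-fold lower number from compound 1 to compound 2 (1.79 log units; beyond the scatter), was large and beyond the scatter. However, it exchanged a (thiophen-2-yl)sulfonyl for cyclohexylmethyl on the amine nitrogen, so it does not compare the two groups at issue here. Only a modest shift, not beyond the scatter, is therefore expected in this assay. The expected step is a 1.6-fold lower number from compound 2 to compound 3 (0.20 log units; within the scatter). The estimate for compound 3 is 100 nM, with an expected range of 35 nM to 300 nM.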

Compound 3, concentration for 50% growth inhibition: 380 nM
Estimate against measurement, compound 3: 3.8-fold (0.58 log units) below, and the stated range ends below it.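

In this assay, the exchange of cyclohexylmethyl for 4-fluorobenzyl is not neutral: it gives a 2.4-fold higher number from compound 2 to compound 3 (0.38 log units; beyond the scatter), so at this place on the amine nitrogen the 4-fluorophenyl group does somewhat worse than cyclohexyl. Even so, 4-fluorobenzyl retains far more growth inhibition than the (thiophen-2-yl)sulfonyl group, with an at least 26-fold lower number from compound 1 to compound 3 (1.42 log units; beyond the scatter). The value of compound 1 is a limit of the assay and not a number, so this step has no fixed size, because that compound sits at the limit: the limit of > 10000 nM in this assay, at which 1 of the 3 values shown sits.

On these data alone, whether the loss comes from the aromatic ring itself or from the fluorine stays open, and an unsubstituted benzyl group would separate the two. As far as these compounds go, how a longer chain such as cyclohexylethyl would compare also remains unknown.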